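Replacing the aryl group of compound 3

This account rests on a few compounds, and the source may have more. Where it says the series, first, only, none or still open, it means among the compounds named here.

In a functional assay (aorta) with Oryctolagus cuniculus as the target (on this read-out higher numbers stand for weaker binding and lower numbers for tighter binding), compound 1 (`COc1ccc(C(c2ccc(OC)cc2)C2CCN(CCCOc3ccc(C(C)=O)cc3OC)CC2)cc1`) gives 10 nM and compound 3 (`COc1cc(C(C)O)ccc1OCCCN1CCC(C(c2ccc(F)cc2)c2ccc(F)cc2)CC1`) gives 10 nM as well, so these two share the highest number of the three. Compound 2 (`COc1cc(C(C)=O)ccc1OCCCN1CCC(C(O)(c2ccc(F)c(F)c2)c2ccc(F)c(F)c2)CC1`) gives 2.51 nM on the same read-out, a lower number than that of compound 3 and beyond the scatter. Compound 4 (`COc1cc(OCCCN2CCC(C(c3ccc(F)cc3)c3ccc(F)cc3)CC2)ccc1C(C)=O`) carries 4-acetyl-3-methoxyphenyl in place of the 4-(1-hydroxyethyl)-2-methoxyphenyl of compound 3, on an oxygen on a saturated carbon (4-acetyl-3-methoxyphenyl in place of 4-(1-hydroxyethyl)-2-methoxyphenyl on an oxygen on a saturated carbon). Among the measured compounds shown here, no measured pair isolates this change, and the three values give it no direction. The estimated change (no change at the digits printed from compound 3 to compound 4 (within the scatter)) is expected to stay within the scatter. In this assay compound 4 is expected at 10 nM with an estimated range from 3 nM to 32 nM on this read-out.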

Compound 4, dissociation constant: 3.16 nM
Estimate against measurement, compound 4: 3.2-fold (0.50 log units) above, within the range that was stated.
By their numbers in this assay, from the lowest: compounds 2 and 4 (each within the scatter of the next); then compounds 1 and 3 (each within the scatter of the next).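

In this assay, among the compounds shown here, the aryl group on this oxygen proves to matter: 4-acetyl-3-methoxyphenyl in place of 4-(1-hydroxyethyl)-2-methoxyphenyl brings a 3.2-fold lower number from compound 3 to compound 4 (0.50 log units; beyond the scatter) as the first step in the set that isolates one place. The step is modest, and the entering group counts no hydrogen-bond donor where the leaving group counts one. Nothing at hand explains the lower number.

The swap alters the acetyl or hydroxyethyl group and the methoxy placement together, so the compounds shown do not say which of the two carries the step. They also leave open how an amine or a carboxylic acid in place of the acetyl would read.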